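The compounds below may be only part of what the source reports. "The series", "measured", "known", "first", "only" and "open" are said of these compounds alone.

In a functional assay on HepG2 cells (Homo sapiens) for antiproliferative activity, read by MTT assay, with a stated time of 72 h (a higher number here means a weaker inhibitor, a lower number a stronger inhibitor), compound 1 `O=C(N/N=C/c1ccc(O)cc1)Nc1ccc(Oc2ccnc3[nH]ccc23)c(F)c1` gives 1950 nM and compound 2 `O=C(N/N=C/c1ccc([N+](=O)[O-])cc1)Nc1ccc(Oc2ccnc3[nH]ccc23)cc1` gives 4620 nM. Compound 2 therefore holds the higher of the two numbers, which makes it the weaker inhibitor of the pair, and its gap to compound 1 lies beyond the usual scatter of repeated measurements. The next compound to be tested is compound 3 `O=C(N/N=C/c1ccc(O)cc1)Nc1ccc(Oc2ccnc3[nH]ccc23)cc1`, which has not yet been measured. Its structure puts hydroxy in place of nitro on an aromatic carbon, para to a large group: hydroxy in place of nitro on an aromatic carbon. Going by the values given here, the two measured compounds differ in more than one place, so no measured step shows this change alone. The closest guide is compound 1, which also carries a 4-hydroxyphenyl and stands at 1950 nM. On that basis, the expected change in this assay is a 2.1-fold lower number from compound 2 to compound 3 (0.32 log units; beyond the scatter), a modest step toward a lower number, close to the edge of the scatter. For compound 3 the estimated value is 2200 nM, with an expected range of 800 nM to 6000 nM.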

Compound 3, half-maximal inhibitory concentration: 32200 nM
Estimate against measurement, compound 3: 15-fold (1.17 log units) below; measured number above the stated range.
By their numbers in this assay, from the lowest: compound 1; then compound 2; then compound 3.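

In this assay the aromatic carbon para to a large group proves sensitive to what it carries: hydroxy in place of nitro gives a 7.0-fold higher number from compound 2 to compound 3 (0.84 log units; beyond the scatter) with nothing else altered, so the 4-hydroxyphenyl compound is the weaker of this pair. Hydrogen in place of fluoro on an aromatic carbon, with the 4-hydroxyphenyl kept, gives a 17-fold higher number from compound 1 to compound 3 (1.22 log units; beyond the scatter) and counts as a large step, which shows that the number held by compound 1 belongs to the fluoro-bearing structure and not to the 4-hydroxyphenyl by itself. No measurement is available to explain either step.

The compounds shown leave open whether the fluoro would bring a step of similar size with a 4-nitrophenyl in place of the 4-hydroxyphenyl, since the two changes are seen only with hydroxy in one case and with no fluoro in the other. They also leave open how an amine, a methoxy group or a carboxylic acid on the same aromatic carbon would stand against hydroxy and nitro, and whether chloro would serve in place of fluoro.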